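The compounds below may be only part of what the source reports. "The series", "measured", "known", "first", "only" and "open" are said of these compounds alone.

Compound 1 `FC(F)=C(F)CCSc1nccs1`: in a functional assay on SH-SY5Y cells (Homo sapiens) for cytotoxicity, read by MTT assay, with a stated time of 48 h (on this read-out lower numbers stand for stronger inhibition and higher numbers for weaker inhibition), compound 1 gives > 120000 nM, a limit of the assay rather than a number.
Compound 2 `FC(F)=C(F)CCSc1ncc(-c2ccncc2)s1`: in this assay compound 2 gives > 120000 nM, again only a limit.
Compound 3 `O=S(=O)(CCC(F)=C(F)F)c1ncc(-c2ccncc2)s1`: in this assay compound 3 gives > 120000 nM, also a limit.

Between compound 2 and compound 1 the change is hydrogen in place of pyridin-4-yl on an aromatic carbon, and the step that the two limits leave unreadable from compound 2 to compound 1 cannot be read because of the limit of > 120000 nM in this assay, at which 3 of the 3 values shown sit. How the cores of compound 2 and compound 3 differ is not broken down here. Compound 4 `O=S(=O)(CCC(F)=C(F)F)c1nccs1` arises from compound 3 by hydrogen in place of pyridin-4-yl on an aromatic carbon; the surroundings differ only in that the ring atom nearby bears a group of 8 heavy atoms in one case and a large group in the other, so this is the same kind of change. Compound 4 is expected to show a step that the limit leaves unreadable from compound 3 to compound 4, because compound 3 sits at the limit of > 120000 nM in this assay, at which 3 of the 3 values shown sit. The estimate for compound 4 is 250000 nM.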

Compound 4, half-maximal inhibitory concentration: > 120000 nM
Compound 4 was reported as a limit (the forecaster's own chance of this, stated with the estimate: 85%); the middle value is on the limit's open side.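

Among the compounds shown here, compound 3 and compound 4 both sit at a limit, so no step between them can be read: the limit of > 120000 nM in this assay, at which 4 of the 4 values shown sit. The compounds shown leave open which structural changes, if any, would give a measurable value in this assay.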